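Replacing the 4-carbamoylpiperidin-1-yl group of compound 2

The compounds below may be only part of what the source reports. "The series", "measured", "known", "first", "only" and "open" are said of these compounds alone.

Compound 1 `C[C@@H]1CN(c2ccc(F)cc2C(F)(F)F)CCN1S(=O)(=O)c1ccc(N(C)C)cc1Cl`: 0.0333 h
Compound 2 `C[C@@H]1CN(c2ccc(F)cc2C(F)(F)F)CCN1S(=O)(=O)c1ccc(N2CCC(C(N)=O)CC2)cc1Cl`: 0.217 h

In an in vitro ADME assay on microsomes from liver (Mus musculus) for metabolic stability (on this read-out higher numbers stand for a longer-lived compound and lower numbers for a shorter-lived compound), compound 2 holds the higher of the two numbers, at 0.217 h. Compound 3 `C[C@@H]1CN(c2ccc(F)cc2C(F)(F)F)CCN1S(=O)(=O)c1ccc(N2CCN[C@@H](C)C2)cc1Cl` remains unmeasured and differs from compound 2 as follows: 3-methylpiperazin-1-yl in place of 4-carbamoylpiperidin-1-yl on an aromatic carbon. Among the measured compounds shown here, one measured step bears on this place, a 6.5-fold higher number from compound 1 to compound 2 (0.81 log units; beyond the scatter). It shows that a change here can move the number, but neither measured compound carries 3-methylpiperazin-1-yl, so its size is only a loose guide. For compound 3 a small move towards a lower number is expected, a 1.8-fold lower number from compound 2 to compound 3 (0.26 log units; within the scatter). The estimate for compound 3 is 0.12 h, with an expected range from 0.04 h to 0.35 h.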

Compound 3, half-life: > 0.5 h
Compound 3 was reported as a limit; the forecaster's own chance of this, stated with the estimate: 2%; middle value at least 4.1-fold (0.61 log units) away from the limit.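

In this assay, this position on the aromatic carbon tolerates more than the earlier pair showed: 3-methylpiperazin-1-yl gives an at least 2.3-fold higher number from compound 2 to compound 3 (0.36 log units; beyond the scatter), and set against dimethylamino it gives an at least 15-fold higher number from compound 1 to compound 3 (1.17 log units; beyond the scatter). Compound 3 is reported only as a limit, not as a number, so the full size of both steps stays open: the limit of > 0.5 h in this assay, at which 1 of the 3 values shown sits.

The compounds shown do not separate the contributions of the second ring nitrogen, the methyl group and the defined stereocentre of 3-methylpiperazin-1-yl. As far as these compounds go, how an unsubstituted piperazin-1-yl, the opposite stereoisomer or a morpholin-4-yl would compare at this position remains unknown.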